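The source may hold more compounds than are shown below. What is called first, only, known or untested is meant among the compounds shown, and "the series" means these compounds.

Compound 1 `C=CC(=O)NCC#Cc1ccc2ncn(-c3ccnc(N)n3)c2c1`: 6310 nM
Compound 2 `C=Cc1cc(C#Cc2ccc3ncn(-c4ccnc(N)n4)c3c2)ccn1`: 20000 nM
Compound 3 `C#Cc1cc(C#Cc2ccc3ncn(-c4ccnc(N)n4)c3c2)ccn1`: 31600 nM

These three compounds share one core and differ only in the group carried on the triple-bonded carbon. In an assay on Sf9 cells for inhibition of mitogen-activated protein kinase kinase kinase 14 variant S549D (Homo sapiens), with a stated time of 30 min, in the presence of a further agent that is not named here (a lower number here means a stronger inhibitor, a higher number a weaker inhibitor), compound 3 gives 31600 nM, the highest of the three numbers. The gap to compound 1 is beyond the scatter, as the step of a 5.0-fold higher number from compound 1 to compound 3 (0.70 log units; beyond the scatter) shows, whereas the gap to compound 2, a 1.6-fold higher number from compound 2 to compound 3 (0.20 log units; within the scatter), is within the scatter, so those two cannot be told apart.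

Compound 4 `C#Cc1cc(C#Cc2ccc3ncn(-c4ccnc(N)n4)c3c2)ncn1` is not yet measured. It differs from compound 3 in one place: a group of 8 heavy atoms (6 carbon, 2 nitrogen; one six-membered aromatic ring with 2 hetero atoms) in place of a group of 8 heavy atoms (7 carbon, 1 nitrogen; one six-membered aromatic ring with 1 hetero atom), on a triple-bonded carbon. Within the data shown here, no measured step swaps one ring for another of the same size. The steps that touch this position are a 3.2-fold higher number from compound 1 to compound 2 (0.50 log units; beyond the scatter), a 5.0-fold higher number from compound 1 to compound 3 (0.70 log units; beyond the scatter) and a 1.6-fold higher number from compound 2 to compound 3 (0.20 log units; within the scatter), all modest or within the scatter, and each comes from a larger change than the one here. No step beyond the scatter is therefore expected in this assay for compound 4. The estimate for compound 4 is 31600 nM, between 10000 nM and 100000 nM. This estimate means an expected step of no change at the digits printed from compound 3 to compound 4 (within the scatter).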

Compound 4, half-maximal inhibitory concentration: 50100 nM
Compound 4: the middle estimate sits 1.6-fold (0.20 log units) below what was measured; the range from low to high includes it.
By their numbers in this assay, from the lowest: compound 1; then compounds 2, 3 and 4 (each within the scatter of the next, the first and the last beyond it).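

Replacing the ring carrying one hetero atom with one carrying two, while keeping the ethynyl group, gives a 1.6-fold higher number from compound 3 to compound 4 (0.20 log units; within the scatter), so this first ring-for-ring swap on the triple-bonded carbon has no readable effect, even though the count of hydrogen-bond acceptors rises. The gap from the vinyl compound does lie beyond the scatter, at a 2.5-fold higher number from compound 2 to compound 4 (0.40 log units; beyond the scatter), although that pair differs in the end group as well as in the ring. The widest gap in the set is a 7.9-fold higher number from compound 1 to compound 4 (0.90 log units; beyond the scatter), and compounds 2, 3 and 4, which all carry an aromatic ring at this place, have higher numbers than compound 1, which carries the open chain.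

Nothing measured here gives a reason for these steps. Also open, on these data alone, is whether an amine or a carboxylic acid on the ring, in place of ethynyl, would bring the number down towards that of compound 1.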